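Sulfonyl aryl variation at the ring sulfonamide nitrogen

The compounds below may be only part of what the source reports. "The series", "measured", "known", "first", "only" and "open" are said of these compounds alone.

Compound 1 `Cc1ccc2[nH]c(C(=O)N[C@H]3CN(S(=O)(=O)c4cccnc4)C[C@@H]3C(=O)NCCN(C)C)cc2c1` and compound 2 `Cc1ccc2[nH]c(C(=O)N[C@H]3CN(S(=O)(=O)c4cnccn4)C[C@@H]3C(=O)NCCN(C)C)cc2c1` share one core and differ only at the sulfonyl aryl group. In a functional assay on HEK293 cells for agonist activity at growth hormone secretagogue receptor type 1 (Homo sapiens), read by HTRF and inositol phosphate accumulation, with a stated time of 90 min, in the presence of a further agent that is not named here (on this read-out higher numbers stand for larger maximal responses and lower numbers for smaller maximal responses), compound 1 gives 90% and compound 2 gives 92%; the change a number 2 percentage points higher from compound 1 to compound 2 (within the scatter) stays inside the scatter. Compound 3 `Cc1ccc2[nH]c(C(=O)N[C@H]3CCN(S(=O)(=O)c4ccccc4)C[C@@H]3C(=O)NCCN(C)C)cc2c1`, built on a different core, carries a phenylsulfonyl group and in this assay compound 3 gives 98%, the highest of the three numbers, though its distances to compound 2 and compound 1 both lie within the scatter, so no order among the three can be claimed.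

Compound 4 `Cc1ccc2[nH]c(C(=O)N[C@H]3CCN(S(=O)(=O)c4cccnc4)C[C@@H]3C(=O)NCCN(C)C)cc2c1` keeps the core of compound 3 and is changed as follows: pyridin-3-yl in place of phenyl on a sulfonyl sulfur. Among the compounds with values here, no measured step matches this exchange directly; the only measured step at the same position, the aryl exchange from compound 1 to compound 2, was within the scatter, and the three aryl sulfonamides so far all reach a similar maximal response. On that basis the step of a number 4 percentage points lower from compound 3 to compound 4 (within the scatter) is expected to stay within the scatter in this assay. For compound 4 the estimate in this assay is 94%, with a range from 82% to 104%.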

Compound 4, largest response reached (Emax), in percent of the reference or control that the assay uses: 93%
Estimate against measurement, compound 4: 1 percentage points above; the range from low to high includes it.
By their numbers in this assay, from the lowest: compounds 1, 2, 4 and 3 (each within the scatter of the next).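

Within the data shown here, the step of a number 5 percentage points lower from compound 3 to compound 4 (within the scatter) is the first exchange at this position between an aromatic ring of carbon only and one with a ring nitrogen, whereas the earlier step at the sulfonyl sulfur linked two aryl groups that both carry ring nitrogens. It also places the same (pyridin-3-yl)sulfonyl group on both cores, and in this assay compound 1 gives 90% while compound 4 gives 93%, so the series now holds a pair that differs only in the core. Nothing available bears on the reason for these numbers, and no explanation can be offered for them.

The compounds shown leave open whether the maximal response stays in this range with a non-aromatic group on the sulfonyl sulfur, such as methyl or cyclopropyl, or with a phenyl carrying a carboxylic acid or an amine. They also leave open what happens if a carbonyl takes the place of the sulfonyl link, since all four compounds keep that sulfonamide and differ only in the aryl group or the core.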